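Extending the Ring Nitrogen Substituent by One Carbon

A few compounds are considered here, and "the series" means these few. Any claim that something is new, unique, unknown or untested is made for them only; others in the source may bear on it.

Compound 1 `COc1cccc(NC(=O)NC2=NC(=O)CN2C)c1`: 2800 nM
Compound 2 `Cc1ccc(NC(=O)NC2=NC(=O)CN2C)nc1`: 3100 nM
Compound 3 `CC1C(=O)N=C(NC(=O)Nc2cccc(Cl)c2)N1C`: 490 nM

In a functional assay for inhibition of metabotropic glutamate receptor 5 (Homo sapiens), read by FLIPR and calcium flux (on this read-out higher numbers stand for weaker inhibition and lower numbers for stronger inhibition), compound 3 gives the lowest number of the three, and both compound 1 and compound 2 lie beyond the scatter above it, so compound 3 is the strongest inhibitor among them. Compound 4 `CCN1C(NC(=O)Nc2cccc(Cl)c2)=NC(=O)C1C` keeps everything of compound 3 and differs only in methyl in place of hydrogen on a saturated chain carbon bound to an amine nitrogen in a ring. For the measured compounds named here, no pair of measured compounds shows such a change, so nothing here says which way it should move. With only one carbon added, the step from compound 3 to compound 4 is expected to be small, most likely within the scatter, in either direction: a 1.1-fold higher number from compound 3 to compound 4 (0.05 log units; within the scatter). Compound 4 is therefore estimated at 550 nM, with a plausible range from 200 nM to 1600 nM.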

Compound 4, half-maximal inhibitory concentration: 410 nM
The estimate for compound 4 lay 1.3-fold (0.13 log units) above the measured number; measured number inside the range.
By their numbers in this assay, from the lowest: compounds 4 and 3 (each within the scatter of the next); then compounds 1 and 2 (each within the scatter of the next).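

In this assay, going from methyl to ethyl on the saturated chain carbon bound to an amine nitrogen in a ring gives a 1.2-fold lower number from compound 3 to compound 4 (0.08 log units; within the scatter) and so leaves the reading unchanged. For the compounds shown here, this place therefore takes an ethyl as readily as a methyl, which no earlier pair of compounds could show. No measurement at hand explains this result. On these data alone, whether a longer chain such as propyl or butyl would also be accepted here remains open. So does the effect of a chain ending in an amine or a carboxylic acid.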